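This account rests on a few compounds, and the source may have more. Where it says the series, first, only, none or still open, it means among the compounds named here.

Measured in a functional assay on U-937 cells (Homo sapiens) for antiproliferative activity, read by MTT assay, with a stated time of 72 h; a higher number here means a weaker inhibitor, a lower number a stronger inhibitor:

- compound 1 `O=C(CCCCCCc1nc(-c2cccnc2)no1)NO`: 350 nM
- compound 2 `Nc1ccccc1NC(=O)CCCCCCc1nc(-c2ccccc2)no1`: 730 nM

Of these two, compound 2 has the higher number and so is the weaker inhibitor, with a gap to compound 1 that lies beyond the usual scatter. The two structures differ in more than one place, so their values do not show the effect of any single change.

Compound 3 `Nc1ccccc1NC(=O)CCCCCCc1nc(-c2ccc([N+](=O)[O-])cc2)no1` keeps the structure of compound 2 except for one change, phenyl to 4-nitrophenyl, with nitro in place of hydrogen on an aromatic carbon, para to a large group: nitro in place of hydrogen on an aromatic carbon. Within the data shown here, no measured pair shows what this change does in this assay, so no shift beyond the scatter is expected, in either direction. The expected change is a 1.1-fold higher number from compound 2 to compound 3 (0.04 log units; within the scatter). For compound 3 the estimated value is 800 nM, within an expected range of 280 nM to 2300 nM.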

Compound 3, half-maximal inhibitory concentration: 10300 nM
Beside the measured number, compound 3's estimate is 13-fold (1.11 log units) below it, outside the stated range (above it).
By their numbers in this assay, from the lowest: compound 1; then compound 2; then compound 3.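

Nitro in place of hydrogen on an aromatic carbon, para to a large group, brings a 14-fold higher number from compound 2 to compound 3 (1.15 log units; beyond the scatter) in this assay and so makes compound 3 the weaker inhibitor of the pair. Among these compounds, this is the first single change that can be read here, and it shows that this position on the phenyl ring is not indifferent to what sits on it: one added group alone moves the number sharply upward. Nothing measured here on the nitro group or on these compounds accounts for the loss.

On these data alone, whether the loss belongs to nitro itself or to any group at this position stays open, since an amine, a methoxy group or a fluorine in the same place might behave quite differently. Also open, as far as these compounds go, is whether nitro would cost as much on the core of compound 1.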